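This account rests on a few compounds, and the source may have more. Where it says the series, first, only, none or still open, it means among the compounds named here.

Measured so far in a functional assay (aorta, strain Wistar) for inhibition, with Rattus norvegicus as the target; on this read-out higher numbers stand for weaker inhibition and lower numbers for stronger inhibition:

- compound 1 `CCCCc1nc(Cl)c(COC(=O)CCCCO[N+](=O)[O-])n1Cc1ccc(-c2ccccc2-c2nn[nH]n2)cc1`: 851 nM
- compound 2 `CCCCc1nc(Cl)c(COC(=O)c2cccc(CO[N+](=O)[O-])c2)n1Cc1ccc(-c2ccccc2-c2nn[nH]n2)cc1`: 275 nM

Compound 2, at 275 nM, holds the lower of the two numbers. Compound 3 `CCCCc1nc(Cl)c(COC(=O)c2ccc(CO[N+](=O)[O-])cc2)n1Cc1ccc(-c2ccccc2-c2nn[nH]n2)cc1` has not yet been measured. It differs from compound 2 in one place: 4-((nitrooxy)methyl)phenyl in place of 3-((nitrooxy)methyl)phenyl on a carbonyl carbon. In words, 4-((nitrooxy)methyl)phenyl stands in place of 3-((nitrooxy)methyl)phenyl on a carbonyl carbon. Within the data shown here, only one measured step bears on this change, and only indirectly: a 3.1-fold lower number from compound 1 to compound 2 (0.49 log units; beyond the scatter). That modest step exchanged 4-(nitrooxy)butyl for 3-((nitrooxy)methyl)phenyl, whereas the new change keeps the same atoms. The data hold no measured swap between these two phenyl isomers, so they set no direction. In this assay, no step beyond the scatter is therefore expected. The expected step is a 1.1-fold higher number from compound 2 to compound 3 (0.04 log units; within the scatter). The estimate for compound 3 is 300 nM, with an expected range of 110 nM to 800 nM.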

Compound 3, half-maximal inhibitory concentration: 66.1 nM
Estimate against measurement, compound 3: 4.5-fold (0.66 log units) above; the whole stated range lies above it.
By their numbers in this assay, from the lowest: compound 3; then compound 2; then compound 1.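

In this assay the arrangement on the phenyl ring matters: with the same atoms, 4-((nitrooxy)methyl)phenyl in place of 3-((nitrooxy)methyl)phenyl on the carbonyl carbon gives a 4.2-fold lower number from compound 2 to compound 3 (0.62 log units; beyond the scatter) and so lies beyond the scatter. Set against 4-(nitrooxy)butyl at this same place, the 4-((nitrooxy)methyl)phenyl group gives a 13-fold lower number from compound 1 to compound 3 (1.11 log units; beyond the scatter) and so shows that the earlier exchange of the chain for a phenyl group did not reveal the full span at this position. Nothing at hand accounts for the difference between the two isomers.

The compounds shown cannot tell whether the nitrooxy group itself takes part in this difference, as a hydroxymethyl group on the same phenyl ring might show. They also leave open how a longer chain carrying the nitrooxy group would compare with the phenyl groups.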